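This account rests on a few compounds, and the source may have more. Where it says the series, first, only, none or still open, it means among the compounds named here.

Compound 1 `O=C(Cn1cc(-c2ccc(F)cc2)nn1)Nc1nc2ccccc2s1` — in a functional assay on BMDM cells (Mus musculus, strain C57BL/6) for inhibition, with a stated time of 2 days (a lower number here means a stronger inhibitor, a higher number a weaker inhibitor), compound 1 gives > 30000 nM, which is a limit of the assay rather than a number.
Compound 2 `O=C(Cn1cc(-c2ccc([N+](=O)[O-])cc2)nn1)Nc1nc2ccccc2s1` — in this assay compound 2 gives 3280 nM.

Compound 2 holds the only actual number shown in this assay; the other value shown is a limit. Among the measured compounds shown here, the single measured step, an at least 9.1-fold lower number from compound 1 to compound 2 (0.96 log units; beyond the scatter), is read against (the limit of > 30000 nM in this assay, at which 1 of the 2 values shown sits), so its true size is open at the upper end, but it is beyond the scatter and marks the nitro group as the feature that separates the one number from the limit.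

Compound 3 `O=C(Cn1cc(-c2cccs2)nn1)Nc1nc2ccccc2s1` differs from compound 2 by thiophen-2-yl in place of 4-nitrophenyl on an aromatic carbon. The step from compound 1 to compound 2 bears on this change only in part: compound 3, like compound 1, carries no nitro, but the ring entering is a different one. The expectation is therefore a step towards weaker inhibition, back in the direction of the limit, though not necessarily all the way. Compound 3 is expected to give 15000 nM in this assay, within 4000 nM to 30000 nM, which means an estimated step of a 4.6-fold higher number from compound 2 to compound 3 (0.66 log units; beyond the scatter).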

Compound 3, half-maximal inhibitory concentration: 21400 nM
For compound 3 the middle estimate is 1.4-fold (0.15 log units) below the measured one; measured number inside the range.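

In this assay, thiophen-2-yl in place of 4-nitrophenyl on this aromatic carbon of the five-membered ring gives a 6.5-fold higher number from compound 2 to compound 3 (0.81 log units; beyond the scatter), so the smaller ring does not keep the level reached with the 4-nitrophenyl group. Against the 4-fluorophenyl group the reading is an at least 1.4-fold lower number from compound 1 to compound 3 (0.14 log units; that floor lies within the scatter), and this leaves it undecided whether thiophen-2-yl and 4-fluorophenyl differ at all, even though compound 3 has a number without any nitro group. Compound 1 carries a limit, not a number, so this comparison stays open at the upper end: the limit of > 30000 nM in this assay, at which 1 of the 3 values shown sits.

Going by these compounds, whether the gain seen with the 4-nitrophenyl group belongs to the nitro group itself or to any group at that place on the phenyl ring remains open, and an amine, a nitrile or a carboxylic acid in place of the nitro group would separate these readings. Equally open, on these data alone, is what the thiophene sulfur contributes, which a plain phenyl or a furan-2-yl ring on the same carbon would help to settle.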